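The source may hold more compounds than are shown below. What is called first, only, known or untested is meant among the compounds shown, and "the series" means these compounds.

Series notes, adenosine receptor set. The shared core carries a piperazine whose aryl group varies: compound 1 `Nc1scc(CN2CCN(c3ccc(Cl)cc3F)CC2)c1C(=O)c1ccc(Cl)cc1`, compound 2 `Nc1scc(CN2CCN(c3cccnc3)CC2)c1C(=O)c1ccc(Cl)cc1` and compound 3 `Nc1scc(CN2CCN(c3ccc(F)cc3F)CC2)c1C(=O)c1ccc(Cl)cc1`. In a functional assay on CHO cells with adenosine receptor A1 (Homo sapiens) as the target, read by cAMP accumulation and immunoassay, with a stated time of 6 min, tested at 1 uM (a higher number here means a weaker effect of the compound at the concentration tested, a lower number a stronger effect), compound 1 gives -57%, compound 2 gives -2.7% and compound 3 gives -66%. Compound 3 stands lowest of the three numbers, with compound 1 nearest (a number 9 percentage points lower from compound 1 to compound 3 (within the scatter)) and compound 2 furthest (a number 63.3 percentage points lower from compound 2 to compound 3 (beyond the scatter)); the pyridinyl replacement also shows up as a number 54.3 percentage points higher from compound 1 to compound 2 (beyond the scatter).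

Compound 4 `Nc1scc(CN2CCN(c3c(F)cc(F)cc3F)CC2)c1C(=O)c1ccc(Cl)cc1` differs from compound 3 in one place: fluoro in place of hydrogen on an aromatic carbon, that is 2,4-difluorophenyl to 2,4,6-trifluorophenyl, the new fluoro sitting ortho to a large group and meta to two fluoro groups. Among the measured compounds shown here, the one measured step that bears on a halogen change on this ring, a number 9 percentage points lower from compound 1 to compound 3 (within the scatter), lies within the scatter; the large steps concern the pyridinyl swap, not a halogen. A further fluoro on an already fluorinated phenyl is therefore expected to give no step beyond the scatter in this assay.

Compound 4 is thus estimated at -62%, range -85% to -35%, an expected step of a number 4 percentage points higher from compound 3 to compound 4 (within the scatter).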

Compound 4, a percentage reported as activity, at one concentration (the size of the read-out at that concentration, not a potency): -56%
For compound 4 the middle estimate is 6 percentage points below the measured one; low and high end bracket the measured number.
By their numbers in this assay, from the lowest: compounds 3, 1 and 4 (each within the scatter of the next); then compound 2.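

In this assay, among the compounds shown here, fluoro in place of hydrogen gives the first reading at the aromatic carbon ortho to a large group, and with a number 10 percentage points higher from compound 3 to compound 4 (within the scatter) that position accepts the added fluoro without a step beyond the scatter. The 2,4,6-trifluorophenyl group also stays well apart from pyridin-3-yl, with a number 53.3 percentage points lower from compound 2 to compound 4 (beyond the scatter) as the large step, while a number 1 percentage points higher from compound 1 to compound 4 (within the scatter) places it within the scatter of the 4-chloro-2-fluorophenyl group. No measurement shown gives a reason for these steps.

On these data alone, whether a group larger than fluoro, such as methoxy, trifluoromethyl or an amine, would also leave the number within the scatter at this position remains open. A read-out at a single concentration also leaves open how potency compares across these compounds.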